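This account rests on a few compounds, and the source may have more. Where it says the series, first, only, none or still open, it means among the compounds named here.

Working notes on the series. The shared core carries an acidic side chain with a sulfonyl aryl group and an imidazolylamine substituent on the spiro-fused cyclohexane. In a functional assay for antagonist activity at integrin alpha-5/beta-1 (Homo sapiens), read by ELISA (a lower number here means a stronger inhibitor, a higher number a weaker inhibitor), compound 1 `O=C(NC[C@@H](C(=O)O)S(=O)(=O)c1c(Cl)cccc1Cl)C1=NOC2(CCC(CNc3ncc[nH]3)CC2)C1` gives 3000 nM. Compound 2 `Cc1cc(C)c(S(=O)(=O)[C@@H](CNC(=O)C2=NOC3(CCC(CNc4ncc[nH]4)CC3)C2)C(=O)O)c(C)c1` differs only at the sulfonyl aryl group, and in this assay compound 2 gives 1500 nM; the step of a 2.0-fold lower number from compound 1 to compound 2 (0.30 log units; within the scatter) does not separate the two. Compound 2 therefore stands with compound 1 inside the scatter, the two numbers being indistinguishable on what has been measured.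

Compound 3 `Cc1cc(C)c(S(=O)(=O)[C@@H](CNC(=O)C2=NOC3(CCC(C(=O)Nc4ncc[nH]4)CC3)C2)C(=O)O)c(C)c1` is the next member. The change is (1H-imidazol-2-yl)carbamoyl in place of ((1H-imidazol-2-yl)amino)methyl on a saturated ring carbon. For the measured compounds named here, no measured step touches this position: the single step in hand, from compound 1 to compound 2, concerns the sulfonyl aryl group and says nothing about the substituent on the saturated ring carbon. There is thus no basis for expecting a step in this assay beyond the scatter in either direction. Compound 3 is estimated to give 2000 nM in this assay, with a range of 500 nM to 8000 nM. The step this estimate implies, a 1.3-fold higher number from compound 2 to compound 3 (0.12 log units; within the scatter), is expected to lie within the scatter.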

Compound 3, half-maximal inhibitory concentration: 2700 nM
Beside the measured number, compound 3's estimate is 1.4-fold (0.13 log units) below it, within the range that was stated.
By their numbers in this assay, from the lowest: compounds 2, 3 and 1 (each within the scatter of the next).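

In this assay, for the compounds shown here, the step of a 1.8-fold higher number from compound 2 to compound 3 (0.26 log units; within the scatter) is the first reading at this position, on a saturated ring carbon of the six-membered ring, and it does not separate (1H-imidazol-2-yl)carbamoyl from ((1H-imidazol-2-yl)amino)methyl. The entering group adds one oxygen and one double bond outside aromatic rings, with the counts of hydrogen-bond donors and acceptors unchanged, and with the 2,4,6-trimethylphenyl group on the sulfonyl sulfur this exchange gives no step beyond the scatter. Nothing in hand bears on why the two groups read alike.

As far as these compounds go, both groups at this position carry the 1H-imidazol-2-yl ring, so it remains open whether a plain primary amine, a carboxylic acid or a longer chain linking that ring to the saturated ring carbon would read differently in this assay. From the compounds shown here alone, it also remains open whether the same exchange would read alike with the 2,6-dichlorophenyl group on the sulfonyl sulfur, since the carbamoyl group appears here only with 2,4,6-trimethylphenyl.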